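The compounds below may be only part of what the source reports. "The series", "measured", "known", "first", "only" and "open" are said of these compounds alone.

Compound 1 `Cc1cc(/C=C/C#N)cc(C)c1Oc1nc(Nc2ccc(CN3CCN(S(C)(=O)=O)CC3)cc2)nc2ccsc12` gives 20700 nM in an ADME assay on MT4 cells (Homo sapiens) for cytotoxicity, read by MTT assay, with a stated time of 5 days (a higher number here means that more compound is tolerated, a lower number that less compound is tolerated), the second highest of the three numbers at hand. Compound 2 `Cc1cc(/C=C/C#N)cc(C)c1Oc1nc(Nc2ccc(CN3CCNCC3)cc2)nc2sccc12` gives 4030 nM in this assay, and compound 3 `Cc1cc(/C=C/C#N)cc(C)c1Oc1nc(Nc2ccc(N3CCCC(NS(C)(=O)=O)C3)cc2)nc2sccc12` gives 112000 nM; the gaps between compound 1 and each of these lie beyond the scatter. Compound 4 `Cc1cc(/C=C/C#N)cc(C)c1Oc1nc(Nc2ccc(N3CCNCC3)cc2)nc2ccsc12` arises from compound 1 by piperazin-1-yl in place of (4-(methylsulfonyl)piperazin-1-yl)methyl on an aromatic carbon. Among the compounds with values here, one measured step bears on this change: a 28-fold higher number from compound 2 to compound 3 (1.44 log units; beyond the scatter), a large move when piperazin-1-yl is lost from the side chain. Because compound 2 carries piperazin-1-yl and gives 4030 nM whereas compound 1 gives 20700 nM, the step to compound 4 is expected to lower the number, a 4.1-fold lower number from compound 1 to compound 4 (0.62 log units; beyond the scatter). Compound 4 is therefore estimated at 5000 nM, within 1500 nM to 20000 nM.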

Compound 4, half-maximal cytotoxic concentration: 5730 nM
Beside the measured number, compound 4's estimate is 1.1-fold (0.06 log units) below it, within the range that was stated.
By their numbers in this assay, from the lowest: compounds 2 and 4 (each within the scatter of the next); then compound 1; then compound 3.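

In this assay, within the data shown here, the change on the aromatic carbon para to a large group gives a 3.6-fold lower number from compound 1 to compound 4 (0.56 log units; beyond the scatter), so this position responds on a core where no step had been read. The change removes two features together, the methylsulfonyl and the methyl link, and leaves a smaller group with one hydrogen-bond donor. No measurement here explains the shift.

Which of the two removed features carries the step remains open; (piperazin-1-yl)methyl on the core of compound 1 would separate them. As far as these compounds go, how an acetyl group or a carboxylic acid on the piperazine would read is also open.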